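The compounds below may be only part of what the source reports. "The series", "measured", "known", "first", "only" and "open" are said of these compounds alone.

Compound 2 `c1ccc2c(c1)CN[C@@H](CN(CCCCNCC1CCNCC1)[C@H]1CCCc3cccnc31)C2` gives 36.5 nM in a functional assay on cells for antagonist activity at C-X-C chemokine receptor type 4 (Homo sapiens), read by fluorescence and calcium flux, with stated times of 25 min and 90 s (a lower number here means a stronger inhibitor, a higher number a weaker inhibitor), the lowest of the two numbers shown; compound 1 `c1ccc2c(c1)CN[C@@H](CN(CCCCN(Cc1ccncc1)Cc1ccncc1)[C@H]1CCCc3cccnc31)C2` gives 832 nM, a higher number beyond the scatter. Compound 3 `CC(C)(CN)CCN(C[C@H]1Cc2ccccc2CN1)[C@H]1CCCc2cccnc21` has not been measured; it differs from compound 2 as follows: a group of 5 heavy atoms (4 carbon, 1 nitrogen; no ring) in place of a group of 10 heavy atoms (8 carbon, 2 nitrogen; one six-membered non-aromatic ring with 1 hetero atom), on a saturated chain carbon, two bonds along the chain from an amine nitrogen. Among the compounds with values here, no step between measured compounds isolates this change, so the expectation rests on compound 2 alone. A loss of potency is expected, of a size beyond the scatter, a 6.8-fold higher number from compound 2 to compound 3 (0.84 log units; beyond the scatter). Compound 3 is estimated at 250 nM, with a range from 70 nM to 900 nM.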

Compound 3, half-maximal inhibitory concentration: 69 nM
Compound 3: the middle estimate sits 3.6-fold (0.56 log units) above what was measured, and the stated range ends above it.
By their numbers in this assay, from the lowest: compounds 2 and 3 (each within the scatter of the next); then compound 1.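

In this assay, 1-(aminomethyl)-1-methylethyl in place of the group of 10 heavy atoms with its six-membered non-aromatic ring, on a saturated chain carbon, two bonds along the chain from an amine nitrogen, gives a step within the scatter (a 1.9-fold higher number from compound 2 to compound 3 (0.28 log units; within the scatter)). In this pair, potency at this position therefore does not depend on keeping that ring or the larger group. No measurement available bears on why the two groups read alike.

Open, as far as these compounds go, is whether the terminal amine of the new group is needed: a hydroxyl or a methyl in its place would test this. Also open, from the compounds shown here alone, is how a longer chain carrying the same amine would read.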